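Methyl in place of chloro in compound 3

The source may hold more compounds than are shown below. What is called first, only, known or untested is meant among the compounds shown, and "the series" means these compounds.

Compound 1 `Cc1ccc(S(=O)(=O)N2CCOCC2)cc1C#Cc1cc(Cl)ccc1OCC(=O)O`: 31.7 mL/min/kg
Compound 2 `CC(C)c1ccc(S(C)(=O)=O)cc1C#Cc1cc(Cl)ccc1OCC(=O)O`: 8.33 mL/min/kg
Compound 3 `CS(=O)(=O)c1ccc(Cl)c(C#Cc2cc(Cl)ccc2OCC(=O)O)c1`: 11.7 mL/min/kg

In an in vivo ADME assay on the whole organism (strain BALB/c) for pharmacokinetics, with Mus musculus as the target, read by LC-MS, at a dose of 5 mg/kg by the oral route (a lower number here means slower removal, a higher number faster removal of the compound), compound 3 gives 11.7 mL/min/kg, which lies within the scatter of compound 2 at 8.33 mL/min/kg. Compound 1 gives the highest number of the three at 31.7 mL/min/kg, beyond the scatter of compound 3.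

The next structure is compound 4 `Cc1ccc(S(C)(=O)=O)cc1C#Cc1cc(Cl)ccc1OCC(=O)O`, which has methyl in place of chloro on an aromatic carbon, para to a methylsulfonyl group: methyl in place of chloro on an aromatic carbon. Going by the values given here, only one measured step in this assay falls at this same place. With chloro in place of isopropyl, it is a 1.4-fold higher number from compound 2 to compound 3 (0.15 log units; within the scatter). Among the compounds with values here, no measurement yet covers methyl at this carbon, so the evidence is a single step, and a small one. On that basis, no step beyond the scatter is expected in this assay, in either direction. The expected step is a 1.0-fold higher number from compound 3 to compound 4 (0.01 log units; within the scatter). For compound 4 the estimated clearance is 12 mL/min/kg, with an expected range from 6 mL/min/kg to 24 mL/min/kg.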

Compound 4, clearance: 23.3 mL/min/kg
Estimate against measurement, compound 4: 1.9-fold (0.29 log units) below; the range from low to high includes it.
By their numbers in this assay, from the lowest: compounds 2, 3, 4 and 1 (each within the scatter of the next, the first and the last beyond it).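

In this assay, going by these compounds alone, the aromatic carbon para to a methylsulfonyl group now carries three measured groups, and chloro to methyl there stays within the scatter (a 2.0-fold higher number from compound 3 to compound 4 (0.30 log units; within the scatter)), whereas isopropyl to methyl gives the only step at this position beyond the scatter, a modest one (a 2.8-fold higher number from compound 2 to compound 4 (0.45 log units; beyond the scatter)). On the sulfonyl sulfur, with methyl on the aromatic carbon in both compounds, methyl in place of morpholin-4-yl also stays within the scatter (a 1.4-fold lower number from compound 1 to compound 4 (0.13 log units; within the scatter)). No measurement shown here accounts for any of these steps.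

Going by these compounds, it remains open whether the change from morpholin-4-yl to methyl on the sulfonyl sulfur would also stay within the scatter with chloro or isopropyl on the aromatic carbon. Also open is where an ethyl, a methoxy or a nitrile on that aromatic carbon, or an amine on the sulfonyl sulfur, would fall in this assay relative to the compounds shown.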